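The source may report more compounds than this note shows. Statements on the series, on what has been measured and on what is new or still open speak of the compounds shown alone.

Measured in a functional assay on DU-145 cells (Homo sapiens) for cytotoxicity, read by MTT assay, with a stated time of 48 h; a higher number here means a weaker inhibitor, a lower number a stronger inhibitor:
compound 1, `CCOC(=O)c1c(-c2c(Cl)c3ccccc3oc2=O)nn(-c2ccccc2)c1C(=O)OCC`: 48000 nM
compound 2, `CCOC(=O)c1c(-c2c(Cl)c3cc(C)ccc3oc2=O)nn(-c2ccccc2)c1C(=O)OCC`: 50000 nM
compound 3, `CCOC(=O)c1c(-c2cc3ccc(OCC=C(C)C)cc3oc2=O)nn(-c2ccccc2)c1C(=O)OCC`: 75000 nM

All three sit at the weak end of this assay. Compound 1 and compound 2 share one core; the difference between them is methyl in place of hydrogen on an aromatic carbon, and the step it made is a 1.0-fold higher number from compound 1 to compound 2 (0.02 log units; within the scatter). Compound 3 carries a different core; the difference between the two cores is not broken down here. The numbers for compound 3 and compound 2 lie within the scatter of each other, and so do those for compound 3 and compound 1.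

Compound 4, `CCOC(=O)c1c(-c2cc3ccc(OCC=C(C)C)cc3oc2=O)nn(-c2cccc(C)c2)c1C(=O)OCC`, is not yet measured. It differs from compound 3 by methyl in place of hydrogen on an aromatic carbon. This is the same kind of change as that from compound 1 to compound 2, but the place is not the same: in compound 2 the methyl sits on an aromatic carbon of a six-membered aromatic ring of carbon only, part of a fused or bridged system of two rings, meta to a fused ring and para to a fused ring; in compound 4 it sits on an aromatic carbon of a six-membered aromatic ring of carbon only, meta to a large group. Going by the values given here, one case of methyl in place of hydrogen has a number so far, and it moved the read-out within the scatter. On that basis the step from compound 3 to compound 4 is expected to be small, no change at the digits printed from compound 3 to compound 4 (within the scatter), resting on the step of a 1.0-fold higher number from compound 1 to compound 2 (0.02 log units; within the scatter). Compound 4 is estimated at 75000 nM, within a range from 35000 nM to 160000 nM.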

Compound 4, half-maximal inhibitory concentration: 125000 nM
Compound 4: the middle estimate sits 1.7-fold (0.22 log units) below what was measured; low and high end bracket the measured number.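

In this assay, methyl in place of hydrogen on an aromatic carbon gave a 1.7-fold higher number from compound 3 to compound 4 (0.22 log units; within the scatter), and the two cases of this change agree: the same change on two cores in this assay, a 1.0-fold higher number (0.02 log units; within the scatter) from compound 1 to compound 2 and a 1.7-fold higher number (0.22 log units; within the scatter) from compound 3 to compound 4, 1.6-fold (0.20 log units) apart, within the scatter of two such steps. On the two cores shown, the change therefore leaves the read-out within the scatter, and nothing here separates its effect on one core from its effect on the other. This does not show that the step carries over in a strict sense, since the core and the place both differ between the two cases: in compound 2 the methyl sits on a carbocyclic ring that is part of a fused system, and in compound 4 it sits on a separate phenyl, meta to a large group, so the methyl has not been compared at one place across two cores, and two small steps say little about cores beyond these.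

Still open, from the compounds shown here alone, is whether any group on that phenyl moves the read-out beyond the scatter, as an amine or a carboxylic acid in place of the methyl might. Also open, going by these compounds, is whether a longer chain in place of the ethyl of the esters changes the read-out in this assay.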